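The source may hold more compounds than are shown below. What is called first, only, known or untested is meant among the compounds shown, and "the series" means these compounds.

- compound 1 `COc1ccc(N(C)c2nc(C)nc3ccccc23)cc1OCCCCCC[Se]C#N`: 5520 nM
- compound 2 `Cc1nc(N(C)c2ccc(OCC[Se]C#N)cc2)c2ccccc2n1`: 893 nM

In a functional assay on A549 cells (Homo sapiens) for inhibition, read by MTT assay, with a stated time of 48 h (on this read-out higher numbers stand for weaker inhibition and lower numbers for stronger inhibition), compound 1 gives 5520 nM. This is the higher of the two numbers, so it is the weaker inhibitor of the pair, and its gap to compound 2 at 893 nM lies beyond the usual scatter.

Compound 3 `COc1ccc(N(C)c2nc(C)nc3ccccc23)cc1OCCCC[Se]C#N` has not yet been measured. It differs from compound 1 at the end of the chain: a group of 3 heavy atoms (1 carbon, 1 nitrogen, 1 selenium; no ring) in place of a group of 5 heavy atoms (3 carbon, 1 nitrogen, 1 selenium; no ring), on a saturated chain carbon, four bonds along the chain from an oxygen on an aromatic ring.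

Going by the values given here, no measured pair isolates this change. Compound 2 at 893 nM differs from compound 1 in more than one place, so it offers only a weak hint towards lower numbers. A modest move towards stronger inhibition is expected, and it may not exceed the scatter: the expected step is a 1.7-fold lower number from compound 1 to compound 3 (0.24 log units; within the scatter). The estimated value for compound 3 is 3200 nM, with an expected range of 1100 nM to 8000 nM.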

Compound 3, half-maximal inhibitory concentration: 1200 nM
Compound 3: middle estimate off by 2.7-fold (0.43 log units), on the high side, within the range that was stated.
By their numbers in this assay, from the lowest: compounds 2 and 3 (each within the scatter of the next); then compound 1.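

Going by these compounds alone, with the core of compound 1 held fixed, this is the first comparison that isolates the end of the chain: putting a group of 3 heavy atoms (1 carbon, 1 nitrogen, 1 selenium; no ring) in place of a group of 5 heavy atoms (3 carbon, 1 nitrogen, 1 selenium; no ring) gives a 4.6-fold lower number from compound 1 to compound 3 (0.66 log units; beyond the scatter) in this assay. The two groups differ only in their carbon count, so at this position on a saturated chain carbon, that difference alone is enough to move the number beyond the scatter. Nothing measured here explains the shift.

On these data alone, a single step cannot show a trend, so it remains open how the number would respond to a still shorter chain. As far as these compounds go, the effect of an amine or a carboxylic acid at this chain end is also open.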